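This account rests on a few compounds, and the source may have more. Where it says the series, first, only, none or still open, it means among the compounds named here.

Compound 1 `N#Cc1ccccc1COc1cc(O)c2c(=O)c(O)c(-c3ccccc3)oc2c1` — 22000 nM
Compound 2 `O=c1c(O)c(-c2ccccc2)oc2cc(OCc3ccccc3[N+](=O)[O-])cc(O)c12` — 32000 nM
Compound 3 `N#Cc1cccc(COc2cc(O)c3c(=O)c(O)c(-c4ccccc4)oc3c2)c1` — 72000 nM

In an ADME assay on Huh-5-2 cells (Homo sapiens) for cytotoxicity, read by WST assay, with a stated time of 3 days (a higher number here means that more compound is tolerated, a lower number that less compound is tolerated), compound 3 gives 72000 nM, the highest of the three numbers. The steps of a 3.3-fold higher number from compound 1 to compound 3 (0.51 log units; beyond the scatter) and a 2.3-fold higher number from compound 2 to compound 3 (0.35 log units; beyond the scatter) both lie beyond the scatter, so compound 3 is the best tolerated of the measured set. Compound 4 `COc1cccc(COc2cc(O)c3c(=O)c(O)c(-c4ccccc4)oc3c2)c1` differs from compound 3 by methoxy in place of cyano on an aromatic carbon. Among the compounds with values here, no measured step exchanges exactly these two groups; the nearest comparison is a 1.5-fold higher number from compound 1 to compound 2 (0.16 log units; within the scatter), where one group replaced another on an aromatic carbon and the number stayed within the scatter. On that basis the change is expected to stay within the scatter: a 1.2-fold lower number from compound 3 to compound 4 (0.08 log units; within the scatter). Compound 4 is therefore estimated at 60000 nM, with a range from 25000 nM to 150000 nM.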

Compound 4, half-maximal cytotoxic concentration: > 100000 nM
Compound 4 gave a limit, no number; the forecaster's own chance of this, stated with the estimate: 10%; at least 1.6-fold (0.22 log units) between middle value and limit.
By their numbers in this assay, from the lowest: compounds 1 and 2 (each within the scatter of the next); then compound 3. At a limit, above all of these: compound 4.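

In this assay, as far as these compounds go, compound 4 gives only a limit, not a number: the limit of > 100000 nM in this assay, at which 1 of the 4 values shown sits. The step to it reads an at least 1.3-fold higher number from compound 3 to compound 4 (0.14 log units; that floor lies within the scatter), so methoxy in place of cyano on this aromatic carbon shows no loss of tolerance, though the true size of the change stays unknown. Within the data shown here, the 3-methoxyphenyl group also stands clear of both groups on the earlier compounds, with an at least 3.1-fold higher number from compound 2 to compound 4 (0.49 log units; beyond the scatter) and an at least 4.5-fold higher number from compound 1 to compound 4 (0.65 log units; beyond the scatter).

Open, from the compounds shown here alone, is how an amine, a carboxylic acid or a longer chain on this same aromatic carbon would fare. Also open, going by these compounds, is how far above the limit compound 4 truly lies.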